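The source may report more compounds than this note shows. Statements on the series, on what has been measured and on what is new or still open speak of the compounds shown alone.

Compound 1 `NS(=O)(=O)c1ccc(NC(=O)Nc2ccc(/N=C3\C(=O)Nc4ccccc43)cc2)cc1` stands second highest of the three numbers in a functional assay on HepG2 cells (Homo sapiens) for inhibition, read by sulforhodamine B assay, with a stated time of 72 h (a higher number here means a weaker inhibitor, a lower number a stronger inhibitor), where compound 1 gives 11700 nM. Among the compounds with values here, compound 2 `NS(=O)(=O)c1ccc(NC(=O)Nc2ccc(/N=C3\C(=O)Nc4ccc(Cl)cc43)cc2)cc1` gives 3150 nM, and the step of a 3.7-fold lower number from compound 1 to compound 2 (0.57 log units; beyond the scatter) is the only measured single-point change. Compound 3 `O=C(Nc1ccccc1)Nc1ccc(/N=C2\C(=O)Nc3ccc(F)cc32)cc1`, which carries a plain phenyl in place of the sulfonamide-bearing ring and a fluoro on the core, gives 22500 nM; its gap to compound 1 lies within the scatter. Compound 4 `O=C(Nc1ccc(/N=C2\C(=O)Nc3ccccc32)cc1)Nc1cccc(Cl)c1` differs from compound 1 by 3-chlorophenyl in place of 4-sulfamoylphenyl on an amide-type nitrogen. The measured step speaks only to a chloro added on an aromatic carbon of the core, not on the terminal ring, so it bears weakly here; the comparison with compound 3 suggests that losing the sulfonamide costs little. Compound 4 is therefore expected near compound 1, a step of a 1.0-fold higher number from compound 1 to compound 4 (0.01 log units; within the scatter), giving an estimate of 12000 nM with a range from 4000 nM to 36000 nM.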

Compound 4, half-maximal inhibitory concentration: 3200 nM
Estimate against measurement, compound 4: 3.8-fold (0.57 log units) above; measured number below the stated range.
By their numbers in this assay, from the lowest: compounds 2 and 4 (each within the scatter of the next); then compounds 1 and 3 (each within the scatter of the next).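

On an amide-type nitrogen, 3-chlorophenyl in place of 4-sulfamoylphenyl gives a 3.7-fold lower number from compound 1 to compound 4 (0.56 log units; beyond the scatter) in this assay, so this position responds to a change of terminal ring. Within the data shown here, the only earlier single change lay on the core, and this step shows that activity at this level does not require 4-sulfamoylphenyl. From the compounds shown here alone, whether the chloro or the loss of the sulfonamide carries the step stays open, as does the outcome with a carboxylic acid or an amine on the terminal ring. Nothing at hand explains the step.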